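Phenyl in place of hydrogen on compound 2

The source may hold more compounds than are shown below. What is called first, only, known or untested is meant among the compounds shown, and "the series" means these compounds.

Measured compounds and their numbers in a functional assay on HCT-116 cells (Homo sapiens) for antiproliferative activity, read by CCK-8 assay, with a stated time of 72 h, tested at 2 uM; on this read-out lower numbers stand for a weaker effect and higher numbers for a stronger effect at the one concentration tested:
compound 1 `CC(C)n1cnc2c(Nc3ccccc3)nc(NCOCc3ccc(C(=O)Nc4ccccc4N)cc3)nc21` — 6.85%
compound 2 `Nc1ccccc1NC(=O)c1ccc(COCNc2nc(Nc3ccccc3)c3ncn(C4CCCC4)c3n2)cc1` — 75.2%
compound 3 `CCCCn1cnc2c(Nc3ccccc3)nc(NCOCc3ccc(C(=O)Nc4ccccc4N)cc3)nc21` — 72.9%

Compound 2 holds the highest of the three numbers in this assay, though compound 3 sits within the scatter of it, as a number 2.3 percentage points lower from compound 2 to compound 3 (within the scatter) shows. Within the data shown here, compound 1 lies far beneath both: a number 68.4 percentage points higher from compound 1 to compound 2 (beyond the scatter) and a number 66.1 percentage points higher from compound 1 to compound 3 (beyond the scatter) are the only large steps in the set, and each concerns the group on the aromatic nitrogen.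

Compound 4 `Nc1ccccc1NC(=O)c1ccc(COCNc2nc(Nc3ccc(-c4ccccc4)cc3)c3ncn(C4CCCC4)c3n2)cc1` differs from compound 2 by phenyl in place of hydrogen on an aromatic carbon. Among the measured compounds shown here, none of the measured steps touches this position; all three vary the substituent on the aromatic nitrogen, so no measured step bears on the change from compound 2 to compound 4. The expectation therefore rests only on the high number of compound 2 in this assay, and the expected step of a number 10.2 percentage points lower from compound 2 to compound 4 (beyond the scatter) is set small but with a wide range. For compound 4 the estimate in this assay is 65%, expected between 30% and 90%.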

Compound 4, a percentage reported as inhibition, at one concentration (the size of the read-out at that concentration, not a potency): 9.41%
Beside the measured number, compound 4's estimate is 55.6 percentage points above it, and the stated range ends above it.
By their numbers in this assay, from the lowest: compounds 1 and 4 (each within the scatter of the next); then compounds 3 and 2 (each within the scatter of the next).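

Among these compounds, this position, an aromatic carbon para to a large group, is the first place varied outside the aromatic nitrogen, and in this assay phenyl in place of hydrogen gives a number 65.8 percentage points lower from compound 2 to compound 4 (beyond the scatter), a large step. The read-out therefore depends on this position as well as on the group on the aromatic nitrogen, and with cyclopentyl on that nitrogen the change from phenyl to 4-phenylphenyl does not keep the high number. No measurement at hand accounts for this loss.

The compounds shown leave open whether a methyl, a methoxy or a fluorine at this place would keep the number of compound 2. Also open, as far as these compounds go, is whether a phenyl carrying an amine or a carboxylic acid would behave like the plain phenyl of compound 4.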